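A few compounds are considered here, and "the series" means these few. Any claim that something is new, unique, unknown or untested is made for them only; others in the source may bear on it.

Measured so far:
- compound 1 `CC[C@H](C)[C@H](NC(=O)CN(c1ncnc2c1ncn2C1CCCCO1)C1CC1)C(=O)OCc1ccccc1` gives 16.4% in a functional assay on the whole organism (Tail, strain ICR) with Mus musculus as the target, in the tail flick test, with a stated time of 150 min, at a dose of 25 umol/kg by the oral route; on this read-out lower numbers stand for a weaker effect and higher numbers for a stronger effect at the one dose given
- compound 2 `CC(C)C[C@H](NC(=O)CN(c1ncnc2c1ncn2C1CCCCO1)C1CC1)C(=O)OCc1ccccc1` gives 6.47% in this assay

Compound 2 and compound 1 lie within the scatter of each other: a number 9.9 percentage points lower from compound 1 to compound 2 (within the scatter). Compound 3 `CSCC[C@H](NC(=O)CN(c1ncnc2c1ncn2C1CCCCO1)C1CC1)C(=O)OCc1ccccc1` differs from compound 2 by (methylsulfanyl)methyl in place of isopropyl on a saturated chain carbon, two bonds along the chain from an amide-type nitrogen and a carbonyl carbon. Going by the values given here, only one measured step, a side-chain exchange at the same kind of carbon, bears on this, and it stayed within the scatter; an exchange of one small side chain for another is therefore expected to give no step beyond the scatter, a number 2.5 percentage points higher from compound 2 to compound 3 (within the scatter). Compound 3 is estimated at 9% in this assay, with a range from 0% to 25%.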

Compound 3, a percentage reported as activity, at one dose (the size of the read-out at that dose, not a potency): 17.5%
Compound 3: middle estimate off by 8.5 percentage points, on the low side, and the stated range covers the measured number.
By their numbers in this assay, from the lowest: compounds 2, 1 and 3 (each within the scatter of the next, the first and the last beyond it).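

In this assay, going by these compounds alone, 2-(methylsulfanyl)ethyl in place of isobutyl on the saturated chain carbon gives the first step beyond the scatter (a number 11 percentage points higher from compound 2 to compound 3 (beyond the scatter)). Against sec-butyl, the same chain stays within the scatter (a number 1.1 percentage points higher from compound 1 to compound 3 (within the scatter)), so this side chain separates from isobutyl only, and only modestly. Nothing measured here bears on the reason for this step.

On these data alone, whether an amine or a carboxylic acid on this side chain would give a larger step remains open. Also open, as far as these compounds go, is whether a 2-methoxyethyl chain would match 2-(methylsulfanyl)ethyl.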